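The source may report more compounds than this note shows. Statements on the series, on what has been measured and on what is new or still open speak of the compounds shown alone.

Within the data shown here, compound 1 `CC(C)(C)OC(=O)NCCCNC(=O)CN1CN(c2ccccc2)C2(CCN(C(=O)c3ccc(C4CCCCC4)cc3)CC2)C1=O` is one of three compounds measured in an assay on HEK293 cells for displacement of a labelled ligand from NPC1-like intracellular cholesterol transporter 1 (Homo sapiens) (on this read-out higher numbers stand for weaker inhibition and lower numbers for stronger inhibition), where compound 1 gives 6000 nM. It stands second highest of the three numbers: compound 2 `CC(C)(C)OC(=O)NCCCNC(=O)CN1CN(c2ccccc2)C2(CCN(C(=O)c3ccc(C(C)(C)C)cc3)CC2)C1=O` gives 4500 nM, with a 1.3-fold lower number from compound 1 to compound 2 (0.12 log units; within the scatter), while compound 3 `CC(C)(C)c1ccc(C(=O)N2CCC3(CC2)C(=O)N(CC(=O)N2CCCC(C(N)=O)C2)CN3c2ccccc2)cc1` gives 16900 nM, with a 3.8-fold higher number from compound 2 to compound 3 (0.57 log units; beyond the scatter). The step to the unmeasured compound 4 `NCCNC(=O)CN1CN(c2ccccc2)C2(CCN(C(=O)c3ccc(C4CCCCC4)cc3)CC2)C1=O` alters the chain attached to the amide carbonyl, the same region that changes between compound 2 and compound 3: amino in place of ((tert-butoxycarbonyl)amino)methyl on a saturated chain carbon, two bonds along the chain from an amide-type nitrogen. Among the measured compounds shown here, no measured step removes a tert-butoxycarbonyl group in this way, so the bearing of the measured data is indirect. The step from compound 1 to compound 2 shows that the far aromatic substituent matters little here, and the step from compound 2 to compound 3 shows that reshaping the amide chain can move the number modestly upward. Shortening the chain to a free amino group is therefore expected to change the number only within or just beyond the scatter, with no clear direction; compound 4 is estimated at 7000 nM, in a range from 2500 nM to 20000 nM, which means an expected step of a 1.2-fold higher number from compound 1 to compound 4 (0.07 log units; within the scatter).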

Compound 4, half-maximal inhibitory concentration: 3800 nM
For compound 4 the middle estimate is 1.8-fold (0.27 log units) above the measured one; the range from low to high includes it.
By their numbers in this assay, from the lowest: compounds 4, 2 and 1 (each within the scatter of the next); then compound 3.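

In this assay, the change at this saturated chain carbon, two bonds along the chain from an amide-type nitrogen, gives a 1.6-fold lower number from compound 1 to compound 4 (0.20 log units; within the scatter). A group of 9 heavy atoms, ((tert-butoxycarbonyl)amino)methyl, can therefore give way to amino, a single heavy atom, without the number moving beyond the scatter, so the tert-butoxycarbonyl end of the chain makes no measurable difference on this read-out. Nothing available here explains this result.

The compounds shown leave open whether a different end group on this chain, such as a carboxylic acid or a hydroxyl, or a longer chain ending in amino, would move the number beyond the scatter. They also leave open whether the same change would give a similar result with tert-butyl in place of cyclohexyl on the aromatic ring.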